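Swapping Carboxy for Methyl on the Aryl Tail

This account rests on a few compounds, and the source may have more. Where it says the series, first, only, none or still open, it means among the compounds named here.

Compound 3 `O=C(O)c1ccc(CCCCCC(=O)N2CCOC2=O)cc1` gives, in an assay on HEK293 cells for inhibition of N-acylethanolamine-hydrolyzing acid amidase (Rattus norvegicus), read by LC-MS, with a stated time of 30 min (a lower number here means a stronger inhibitor, a higher number a weaker inhibitor), only a limit rather than a number, > 20000 nM. For comparison, compound 1 `O=C(CCCCCc1ccc(Cl)cc1)N1CCOC1=O` gives 4600 nM in this assay, and compound 2 `O=C(CCCCCc1ccc(Br)cc1)N1CCOC1=O` gives 8510 nM. The bromo-for-chloro change, a 1.9-fold higher number from compound 1 to compound 2 (0.27 log units; within the scatter), is small, whereas the change to carboxy is larger: an at least 4.3-fold higher number from compound 1 to compound 3 (0.63 log units; beyond the scatter) and an at least 2.3-fold higher number from compound 2 to compound 3 (0.37 log units; beyond the scatter). Compound 4 `Cc1ccc(CCCCCC(=O)N2CCOC2=O)cc1` differs from compound 3 by methyl in place of carboxy on an aromatic carbon. The two steps into compound 3 are the ones that bear on this change, and both raised the number, so the reverse direction is expected here; for compound 4 the expected step is an at least 4.0-fold lower number from compound 3 to compound 4 (0.60 log units; beyond the scatter). The estimate for compound 4 is 5000 nM, with a range from 1800 nM to 15000 nM.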

Compound 4, half-maximal inhibitory concentration: 440 nM
Estimate against measurement, compound 4: 11-fold (1.06 log units) above; the whole stated range lies above it.
By their numbers in this assay, from the lowest: compound 4; then compounds 1 and 2 (each within the scatter of the next). At a limit, above all of these: compound 3.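

The earlier compounds shown here showed only that carboxy gave a higher number than chloro or bromo, whereas methyl shows that this position can also give a much lower one, with a 10-fold lower number from compound 1 to compound 4 (1.02 log units; beyond the scatter) and a 19-fold lower number from compound 2 to compound 4 (1.29 log units; beyond the scatter) on the same tail. Going from carboxy to methyl gives an at least 45-fold lower number from compound 3 to compound 4 (1.65 log units; beyond the scatter) and is the widest gap in the set. That step is a bound and not an exact size, since compound 3 stands at a limit: the limit of > 20000 nM in this assay, at which 1 of the 4 values shown sits.

From the compounds shown here alone, what an amine or a methoxy group would give at this place stays open. So does whether methyl keeps its advantage on a longer chain.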